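Shortening the Hydroxycarbamoyl Chain of Compound 2

A few compounds are considered here, and "the series" means these few. Any claim that something is new, unique, unknown or untested is made for them only; others in the source may bear on it.

- compound 1 `CCN(C(=O)c1cc(C(C)C)c(O)cc1O)c1ccc(NC(=O)CCCCCCC(=O)NO)cc1` gives 1380 nM
- compound 2 `CC(C)c1cc(C(=O)N(C)c2ccc(NC(=O)CCCCCCCCC(=O)NO)cc2)c(O)cc1O` gives 210 nM

In a functional assay on NCI-H1975 cells (Homo sapiens) for inhibition, read by sulforhodamine B assay, with a stated time of 48 h (on this read-out higher numbers stand for weaker inhibition of growth and lower numbers for stronger inhibition of growth), compound 2 holds the lower of the two numbers at 210 nM, and the higher number of compound 1 lies beyond the scatter. Compound 3 `CC(C)c1cc(C(=O)N(C)c2ccc(NC(=O)CCCCCCCC(=O)NO)cc2)c(O)cc1O` carries hydroxycarbamoyl in place of (hydroxycarbamoyl)methyl on a saturated chain carbon, seven bonds along the chain from a carbonyl carbon. Going by the values given here, no measured step isolates this change, and compound 1 differs from compound 2 in more than one place. A small move towards weaker inhibition is expected in this assay, possibly within the scatter, with an estimated 1.7-fold higher number from compound 2 to compound 3 (0.22 log units; within the scatter). The estimated value for compound 3 is 350 nM (range 120 nM to 1000 nM).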

Compound 3, concentration for 50% growth inhibition: 400 nM
Compound 3: middle estimate off by 1.1-fold (0.06 log units), on the low side; the measured number falls inside the stated range.
By their numbers in this assay, from the lowest: compounds 2 and 3 (each within the scatter of the next); then compound 1.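

In this assay, hydroxycarbamoyl in place of (hydroxycarbamoyl)methyl on a saturated chain carbon, seven bonds along the chain from a carbonyl carbon, gives a 1.9-fold higher number from compound 2 to compound 3 (0.28 log units; within the scatter). Going by these compounds alone, this is the first single-place reading at this position, and it does not separate the two chain lengths, so compound 2 and compound 3 stand level here. Nothing at hand accounts for this result. Still open, from the compounds shown here alone, is how a carboxylic acid in place of hydroxycarbamoyl at this chain end would read, and whether a longer chain would read any differently.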